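The compounds below may be only part of what the source reports. "The series", "measured", "known", "first", "only" and "open" are said of these compounds alone.

Measured so far in this assay:
compound 1 `O=C(/C=C\c1ccccc1F)N1N=C(c2ccncc2)OC1c1c[nH]c2ccccc12` — > 30 ug/mL, a limit of the assay
compound 2 `O=C(/C=C\c1ccccc1Cl)N1N=C(c2ccncc2)OC1c1c[nH]c2ccccc12` — > 30 ug/mL, a limit of the assay

In an ADME assay on A549 cells (Homo sapiens) for cytotoxicity, read by MTT assay, with a stated time of 48 h (on this read-out lower numbers stand for stronger inhibition of growth and higher numbers for weaker inhibition of growth), compound 1 gives > 30 ug/mL, which is a limit and not a number. Compound 2 likewise gives > 30 ug/mL, again a limit. Going by the values given here, both values sit at the limit of > 30 ug/mL in this assay, at which 2 of the 2 values shown sit, so the only measured step, a step that the two limits leave unreadable from compound 1 to compound 2, cannot be read in either direction or size. Compound 3 `O=C(/C=C\c1ccc(Cl)cc1Cl)N1N=C(c2ccncc2)OC1c1c[nH]c2ccccc12` differs from compound 2 by chloro in place of hydrogen on an aromatic carbon. Among the compounds with values here, no readable step among the measured compounds bears on this change; the one step recorded, from compound 1 to compound 2, is hidden by the limits at which both compounds stand. The expectation is therefore that compound 3 stays at the same limit, with a step of a number no higher from compound 2 to compound 3 (the limit leaves the size open) that cannot be distinguished from none. Compound 3 is estimated at 30 ug/mL, with a range from 15 ug/mL to 60 ug/mL.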

Compound 3, concentration for 50% growth inhibition: > 30 ug/mL
Compound 3 was reported as a limit; the forecaster's own chance of this, stated with the estimate: 80%; the middle value sits exactly at the limit.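

In this assay, going by these compounds alone, compound 1, compound 2 and compound 3 each stand at a limit and not at a number, so no step among them can be read: (the limit of > 30 ug/mL in this assay, at which 3 of the 3 values shown sit). The compounds shown leave open how strongly each inhibits growth, and whether chloro in place of fluoro, or the added chloro, changes that at all.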